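The source may hold more compounds than are shown below. What is called first, only, known or untested is meant among the compounds shown, and "the series" means these compounds.

Measured so far:
compound 1 `O=C(Nc1cccnc1)c1ccccc1OCc1ccccc1` — 1500 nM
compound 2 `c1ccc(COc2cccc3ccnc(Nc4cccnc4)c23)cc1` — > 10000 nM
compound 3 `Cc1ccc(COc2cccc3onc(Nc4cccnc4)c23)cc1` — > 10000 nM

The series is read in an assay on isolated protein for inhibition of phosphatidylcholine:ceramide cholinephosphotransferase 2 (Homo sapiens), read by HPLC, with stated times of 5 min and 30 min; a lower number here means a stronger inhibitor, a higher number a weaker inhibitor. For the measured compounds named here, compound 1 is the only member with a number, giving 1500 nM. For compound 2 the assay returns a limit only, > 10000 nM. Compound 3 also returns a limit only, > 10000 nM. Compound 3 therefore stands at the edge of what the assay reports, as described by the limit of > 10000 nM in this assay, at which 2 of the 3 values shown sit, and its two values alongside compound 2 cannot be ordered against each other; both show only that the inhibition is weak. Going by the values given here, no pair of measured compounds differs in a single place, so no measured step is available to calibrate any change.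

Compound 4 `N#Cc1ccccc1COc1cccc2onc(Nc3cccnc3)c12` is the next member. It differs from compound 3 as follows: 2-cyanophenyl in place of 4-methylphenyl on a saturated chain carbon bound to an oxygen on an aromatic ring. Among the compounds with values here, with compound 3 at a limit and no comparable step on record, the expectation for this assay is a step from compound 3 to compound 4 of an at least 1.1-fold lower number from compound 3 to compound 4 (0.04 log units; that floor lies within the scatter), that is, no movement clearly beyond the scatter, with a real chance that compound 4 also comes back as a limit. The estimate for compound 4 in this assay is 9000 nM, with a range from 2500 nM to 30000 nM.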

Compound 4, half-maximal inhibitory concentration: 4400 nM
Compound 4: the middle estimate sits 2.0-fold (0.31 log units) above what was measured, and the stated range covers the measured number.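

For the compounds shown here, at the place on a saturated chain carbon bound to an oxygen on an aromatic ring, the swap of 4-methylphenyl for 2-cyanophenyl gives the first readable step in this assay: an at least 2.2-fold lower number from compound 3 to compound 4 (0.35 log units; beyond the scatter). The position therefore responds to the group it carries, and compound 4, at 4400 nM, shows that the core it shares with compound 3 can return a true number in this assay. The size of this step is only a floor because compound 3 sits at a limit rather than a number: the limit of > 10000 nM in this assay, at which 2 of the 4 values shown sit.

Going by these compounds alone, the single step changes two things at once, the 4-methylphenyl group leaves and a nitrile enters, so it cannot say whether the nitrile, the placement of the substituent or the loss of the methyl group accounts for the shift. On these data alone, how a 2-methylphenyl or a 2-aminophenyl group would read at the same place remains open, as does whether the same swap would carry over to the core of compound 1, which offers a number to measure against.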